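Replacing pyrrolidin-1-yl with oxan-2-yl: a step from a limit

This account rests on a few compounds, and the source may have more. Where it says the series, first, only, none or still open, it means among the compounds named here.

Measured so far in a physicochemical assay for solubility; on this read-out higher numbers stand for higher solubility and lower numbers for lower solubility
Compound 1 `C[C@H](Oc1ccc(S(C)(=O)=O)cc1C(=O)N1Cc2ccc(N3CCCC3)cc2C1)C(F)(F)F` gives < 1 ug/mL as a limit
Compound 2 `C[C@H](Oc1ccc(S(C)(=O)=O)cc1C(=O)N1Cc2cnc(C(F)(F)F)cc2C1)C(F)(F)F` gives 470 ug/mL

In this assay compound 1 gives < 1 ug/mL and stands at a limit of the assay, not at a number. Compound 3 `C[C@H](Oc1ccc(S(C)(=O)=O)cc1C(=O)N1Cc2ccc(C3CCCCO3)cc2C1)C(F)(F)F` keeps the core of compound 1 but has oxan-2-yl in place of pyrrolidin-1-yl on an aromatic carbon. For the measured compounds named here, no measured pair shows this change, so the expectation is tentative. In this assay the expected move is a modest rise, estimated as an at least 5.0-fold higher number from compound 1 to compound 3 (0.69 log units; beyond the scatter) here. For compound 3 the estimated value is 5 ug/mL with an expected range from 1 ug/mL to 30 ug/mL in this read-out.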

Compound 3, solubility: < 1 ug/mL
Compound 3: no number, only a limit; the forecaster's own chance of this, stated with the estimate: 30%; middle value at least 5.0-fold (0.69 log units) away from the limit.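

For the compounds shown here, compound 1 and compound 3 both stand at a limit of this assay, not at a number, so no step between them can be read: the limit of < 1 ug/mL in this assay, at which 2 of the 3 values shown sit. On these data alone, whether oxan-2-yl in place of pyrrolidin-1-yl changes this read-out at all remains open.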